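Biaryl anilines: methoxy for fluoro on the distal ring

A few compounds are considered here, and "the series" means these few. Any claim that something is new, unique, unknown or untested is made for them only; others in the source may bear on it.

Measured so far:
compound 1 `Oc1ccccc1CNc1ccc(F)cc1`: "not active" (no number reported)
compound 2 `Oc1ccccc1CNc1ccc(-c2cccc(F)c2)cc1`: 2020 nM

In a functional assay on Jurkat cells (Homo sapiens) for activation, with a stated time of 24 h (on this read-out higher numbers stand for an effect only at larger amounts of compound and lower numbers for an effect already at smaller amounts), compound 1 `Oc1ccccc1CNc1ccc(F)cc1` is recorded as "not active" (no number reported); this entry carries no number. Compound 2 `Oc1ccccc1CNc1ccc(-c2cccc(F)c2)cc1` gives in this assay a value of 2020 nM. Compound 2 therefore holds the only number shown for this series, and the other entry offers nothing to set against it, so no step between measured compounds can be stated and no direction of change within the series is known.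

Compound 3 `COc1cccc(-c2ccc(NCc3ccccc3O)cc2)c1` differs from compound 2 by methoxy in place of fluoro on an aromatic carbon. Among the compounds with values here, no measured pair shows how this swap behaves here. The group that enters is small and the rest of the molecule is unchanged, so the step from compound 2 to compound 3 in this assay is expected to be a 1.2-fold higher number from compound 2 to compound 3 (0.09 log units; within the scatter), which is not beyond the usual scatter, with wide uncertainty on either side. Compound 3 is accordingly estimated at 2500 nM, with a plausible range from 800 nM to 8000 nM.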

Compound 3, half-maximal effective concentration: "not active" (no number reported)
Compound 3 has no reported number here, and the estimate cannot be compared.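

Within the data shown here, compound 3 carries no number, so no step from compound 2 to compound 3 can be read, and compound 1 offers none either. No available evidence bears on this result. The compounds shown leave open how methoxy and fluoro compare at this place on the shared core, with compound 2 alone holding a number.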